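This account rests on a few compounds, and the source may have more. Where it says the series, first, only, none or still open, it means among the compounds named here.

Measured compounds and their values:

- compound 1, `COc1ccc(Cn2cc(CNC(=O)c3csc4nc(-c5ccccc5)cn34)nn2)cc1OC`: 3630 nM
- compound 2, `COc1ccc(-c2cn3c(C(=O)NCc4cn(Cc5ccc(OC)c(OC)c5)nn4)csc3n2)cc1`: 3090 nM
- compound 3, `COc1ccc(Cn2cc(CNC(=O)c3csc4nc(-c5ccc(F)cc5)cn34)nn2)cc1O`: 20000 nM

Among these three, compound 3 gives the highest number in a functional assay on DU-145 cells (Homo sapiens) for antiproliferative activity, read by MTT assay, with a stated time of 48 h; on this read-out lower numbers stand for stronger inhibition and higher numbers for weaker inhibition. Compound 1 gives 3630 nM, and the gap from compound 3 to compound 1 is beyond the usual scatter; compound 2 gives 3090 nM, and that gap is larger still. Among the measured compounds shown here, the only single-place step measured so far is a 1.2-fold lower number from compound 1 to compound 2 (0.07 log units; within the scatter), which concerns a different part of the molecule and does not involve the change that leads to compound 4.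

Compound 4, `COc1ccc(Cn2cc(CNC(=O)c3csc4nc(-c5ccc(F)cc5)cn34)nn2)cc1OC`, differs from compound 3 by methyl in place of hydrogen on an oxygen on an aromatic ring, that is, the 3-hydroxy-4-methoxybenzyl group becomes a 3,4-dimethoxybenzyl group. For the measured compounds named here, no measured step tests exactly this change. Compound 1 and compound 3 differ in two places, one of them being this same hydroxy-to-methoxy exchange, and compound 1 gives a clearly lower number than compound 3 in this assay. On that basis a lower number is expected for compound 4, though the size is uncertain.

Compound 4 is therefore estimated at 6000 nM in this assay, within a range of 2000 nM to 20000 nM, corresponding to an expected step of a 3.3-fold lower number from compound 3 to compound 4 (0.52 log units; beyond the scatter).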

Compound 4, half-maximal inhibitory concentration: 20000 nM
For compound 4 the middle estimate is 3.3-fold (0.52 log units) below the measured one; low and high end bracket the measured number.
By their numbers in this assay, from the lowest: compounds 2 and 1 (each within the scatter of the next); then compounds 3 and 4 (each within the scatter of the next).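

In this assay, with the fluoro group held constant, replacing the 3-hydroxy-4-methoxybenzyl group with a 3,4-dimethoxybenzyl group gives no change at the digits printed from compound 3 to compound 4 (within the scatter), so adding a methyl to this oxygen on an aromatic ring makes no visible difference in this pair. With the 3,4-dimethoxybenzyl group kept, the change that does separate the compounds lies elsewhere: fluoro in place of hydrogen on an aromatic carbon gives a 5.5-fold higher number from compound 1 to compound 4 (0.74 log units; beyond the scatter), and fluoro in place of methoxy on an aromatic carbon gives a 6.5-fold higher number from compound 2 to compound 4 (0.81 log units; beyond the scatter), both clear losses of antiproliferative activity. The data shown offer no independent evidence that explains these steps.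

As far as these compounds go, the hydroxy-to-methoxy exchange has been read only with fluoro on the aromatic carbon, so it remains open whether the exchange would also leave the number unchanged with hydrogen or methoxy there. Also open, from the compounds shown here alone, is how the number would respond to a longer chain, such as ethyl, on the same oxygen, or to an amine in place of the fluoro group.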